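Swapping benzylamino for 3,4-difluorophenyl in compound 2

The source may hold more compounds than are shown below. What is called first, only, known or untested is meant among the compounds shown, and "the series" means these compounds.

This piece follows compound 2 `CN1CCC(C(=O)N2Cc3c(NC(=O)NCc4ccccc4)n[nH]c3C2(C)C)CC1` in a functional assay on A2780 cells (Homo sapiens) for antiproliferative activity, read by fluorescence, with a stated time of 72 h; a lower number here means a stronger inhibitor, a higher number a weaker inhibitor. There compound 2 gives 2680 nM, and compound 3 `CC(C)(C)C(=O)N1Cc2c(NC(=O)c3ccc(F)cc3)n[nH]c2C1(C)C` gives 270 nM, a lower number by a gap beyond the scatter. Compound 1 `CC(=O)N1CCN(C(=O)N2Cc3c(NC(=O)c4ccc(F)cc4)n[nH]c3C2(C)C)CC1` gives > 10000 nM, which is a limit and not a number.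

Compound 4 `CN1CCC(C(=O)N2Cc3c(NC(=O)c4ccc(F)c(F)c4)n[nH]c3C2(C)C)CC1` has not been measured yet. It differs from compound 2 in one place: 3,4-difluorophenyl in place of benzylamino on a carbonyl carbon. In words, 3,4-difluorophenyl stands in place of benzylamino on a carbonyl carbon.

Among the compounds with values here, no measured step makes this exact change. Within the data shown here, the only step available, an at least 37-fold lower number from compound 1 to compound 3 (1.56 log units; beyond the scatter), is large and swaps a different group, so it shows only that single changes in this family can move the number a long way. Compound 3 carries a similar fluorinated ring on that carbonyl and gives 270 nM, which suggests that a lower number is to be expected. Compound 1 carries that ring too and goes against this, so the expectation stays moderate and uncertain.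

The expected change is a 3.8-fold lower number from compound 2 to compound 4 (0.58 log units; beyond the scatter), towards a stronger inhibitor in this assay. For compound 4 the estimate is 700 nM, with an expected range from 150 nM to 3000 nM.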

Compound 4, half-maximal inhibitory concentration: 100 nM
Beside the measured number, compound 4's estimate is 7.0-fold (0.85 log units) above it; measured number below the stated range.
By their numbers in this assay, from the lowest: compound 4; then compound 3; then compound 2. At a limit, above all of these: compound 1.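

In this assay, within the data shown here, replacing benzylamino with 3,4-difluorophenyl on a carbonyl carbon gives a 27-fold lower number from compound 2 to compound 4 (1.43 log units; beyond the scatter), the first measured step at this place in the molecule. Among these compounds, the only earlier step changed a different group, so this result adds that the group on this carbonyl carbon can also shift the number strongly while the rest of the molecule stays the same. The two groups have the same number of heavy atoms, and each has one six-membered aromatic ring of carbon only, yet nothing measured here explains why the number falls.

The swap makes several changes at once: the amino nitrogen and its hydrogen-bond donor go, the carbon chain link to the ring goes, and two fluorines arrive, so the size of the step cannot be divided among them. From the compounds shown here alone, a plain phenyl ring, a phenylamino group or a pyridine ring on the same carbonyl carbon would help to separate these changes, and the effect of each remains open.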